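Compound 2 to compound 4: exchanging the side group

The source may hold more compounds than are shown below. What is called first, only, known or untested is meant among the compounds shown, and "the series" means these compounds.

Measured so far in an ADME assay on NIH3T3 cells (Mus musculus) for cytotoxicity; a higher number here means that more compound is needed for the effect, a lower number that less compound is needed (read-out: half-maximal effective concentration):
- compound 1 `Cc1cc(Oc2cccc(Cn3cncn3)c2)cc(C)c1Cl` gives 75900 nM
- compound 2 `Cc1cc(Oc2cccc(Cn3nccn3)c2)cc(C)c1Cl` gives > 100000 nM, a limit of the assay
- compound 3 `Cc1cc(Oc2cccc(Cn3ncc4ccccc43)c2)cc(C)c1Cl` gives > 100000 nM, a limit of the assay

Compound 2 has no number, only the limit > 100000 nM in this assay. The series gathers at the limit of > 100000 nM in this assay, at which 2 of the 3 values shown sit. Among the compounds with values here, compound 1 is the only one with a number.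

The next compound is compound 4 `Cc1nnc(-c2cccc(Oc3cc(C)c(Cl)c(C)c3)c2)s1`, and the change is 5-methyl-1,3,4-thiadiazol-2-yl in place of (2H-1,2,3-triazol-2-yl)methyl on an aromatic carbon. The new group stands on an aromatic carbon of a six-membered aromatic ring of carbon only, meta to a large group.

Within the data shown here, one measured step bears on this, and only loosely: an at least 1.3-fold higher number from compound 1 to compound 2 (0.11 log units; that floor lies within the scatter). It exchanges one triazolyl group for another on the saturated chain carbon, whereas compound 4 has no such chain carbon. Among the measured compounds shown here, no measured step covers that exchange. On these data alone, a step beyond the scatter is therefore not expected, and its direction stays open. The expected step is an at least 1.1-fold lower number from compound 2 to compound 4 (0.04 log units; that floor lies within the scatter), and a reading at the limit is about as likely as a number. The estimate for compound 4 is 90000 nM, with an expected range from 35000 nM to 100000 nM.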

Compound 4, half-maximal effective concentration: > 100000 nM
Compound 4: only a limit was reported; the forecaster's own chance of this, stated with the estimate: 50%; middle value at least 1.1-fold (0.04 log units) away from the limit.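

In this assay, the 5-methyl-1,3,4-thiadiazol-2-yl group stands directly on the aromatic carbon, with no saturated chain carbon, and compound 4 still reads as a limit of the assay, so the chain carbon is not needed to keep a compound at that limit: the limit of > 100000 nM in this assay, at which 3 of the 4 values shown sit.

The step between compound 2 and compound 4 cannot be read, as both are limits, and neither its size nor its direction can be taken from them. Within the data shown here, the only readable step is an at least 1.3-fold higher number from compound 1 to compound 4 (0.11 log units; that floor lies within the scatter); it fixes a floor only, and the true gap between these two compounds may be larger.

On these data alone, with most of the series at the limit, it remains open how far compound 2, compound 3 and compound 4 lie from it, and whether this position moves the read-out at all. Also open, as far as these compounds go, is whether an amine or a carboxylic acid on the same aromatic carbon, meta to a large group, would bring a number into this assay.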